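A few compounds are considered here, and "the series" means these few. Any claim that something is new, unique, unknown or untested is made for them only; others in the source may bear on it.

In a functional assay on HEK293 cells for agonist activity at growth hormone secretagogue receptor type 1 (Homo sapiens), read by HTRF and inositol phosphate accumulation, with a stated time of 90 min, in the presence of a further agent that is not named here (on this read-out higher numbers stand for larger maximal responses and lower numbers for smaller maximal responses), two members of this series have so far been measured. Compound 1 `Cc1ccc2[nH]c(C(=O)N[C@H]3CCN(S(=O)(=O)C4CC4)C[C@@H]3C(=O)NCCN(C)C)cc2c1` reaches 95% in this assay. Compound 2 `Cc1ccc2[nH]c(C(=O)N[C@H]3CN(S(=O)(=O)c4ccccc4)C[C@@H]3C(=O)NC[C@@H]3CCCN3C)cc2c1` reaches 87% in this assay; this is the lower of the two numbers, yet the gap to compound 1 lies within the usual scatter of such measurements, so the two compounds cannot be told apart on this read-out.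

Compound 3 `Cc1ccc2[nH]c(C(=O)N[C@H]3CN(S(=O)(=O)c4ccccc4)C[C@@H]3C(=O)N[C@@H]3CCCNC3)cc2c1` is built from compound 2 by a single change on the amide-type nitrogen: piperidin-3-yl in place of (1-methylpyrrolidin-2-yl)methyl on an amide-type nitrogen. Among the compounds with values here, no pair of measured compounds shows what such a change does on its own, so the expectation for compound 3 can rest only on the fact that both measured compounds, carrying different groups on that amide-type nitrogen, give high maximal responses.

On that ground the step from compound 2 to compound 3 is expected to be a number 1 percentage points higher from compound 2 to compound 3 (within the scatter), that is, none beyond the scatter. Compound 3 is therefore estimated to reach about 88% in this assay, with a range from 74% to 100%, because compound 2 already gives 87%.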

Compound 3, largest response reached (Emax), in percent of the reference or control that the assay uses: 91%
For compound 3 the middle estimate is 3 percentage points below the measured one; low and high end bracket the measured number.
By their numbers in this assay, from the lowest: compounds 2, 3 and 1 (each within the scatter of the next).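

In this assay, within the data shown here, the exchange of (1-methylpyrrolidin-2-yl)methyl for piperidin-3-yl on the amide-type nitrogen gives a number 4 percentage points higher from compound 2 to compound 3 (within the scatter), the first step that can be read at a single place. It shows that this position accepts a six-membered non-aromatic ring in place of a five-membered one, together with an added hydrogen-bond donor, without a shift in maximal response that rises beyond the scatter. Nothing available explains why these two groups give responses that cannot be told apart.

What the compounds shown leave open is how far this tolerance extends: both groups compared here carry a ring nitrogen, so a group such as cyclohexyl, which has no amine, or a short chain ending in a carboxylic acid could show whether an amine on this amide-type nitrogen is needed for so large a maximal response. On these data alone, the role of the defined stereocentre in piperidin-3-yl also remains open, and the opposite mirror-image form of that group would be needed to address it.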